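An Ester Series Still Sitting at the Cytotoxicity Limit

The compounds below may be only part of what the source reports. "The series", "measured", "known", "first", "only" and "open" are said of these compounds alone.

Measured so far:
compound 1 `COc1ccc(OC(=O)c2cn(-c3ccccc3)nc2-c2cccnc2)cc1` — > 100000 nM
compound 2 `CC(C)c1cccc(OC(=O)c2cn(-c3ccccc3)nc2-c2cccnc2)c1` — > 100000 nM

In a functional assay on HeLa cells (Homo sapiens) for cytotoxicity, read by MTT assay, with a stated time of 48 h (on this read-out higher numbers stand for weaker inhibition and lower numbers for stronger inhibition), compound 2 gives > 100000 nM, which is a limit of the assay and not a number. Compound 1 likewise sits at a limit in this assay, where it gives > 100000 nM. For the measured compounds named here, the only step measured between them, a step that the two limits leave unreadable from compound 1 to compound 2, therefore cannot be read. The whole of the evidence is the limit of > 100000 nM in this assay, at which 2 of the 2 values shown sit.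

Compound 3 `CC(C)(C)c1ccc(OC(=O)c2cn(-c3ccccc3)nc2-c2cccnc2)cc1` differs from compound 2 by 4-(tert-butyl)phenyl in place of 3-isopropylphenyl on an oxygen next to a carbonyl group. Going by the values given here, no measured step bears on this change in a readable way, since the step from compound 1 to compound 2 is hidden by the two limits. With both neighbours at the limit, compound 3 is expected to remain there as well, with an expected step that the limit leaves unreadable from compound 2 to compound 3 from compound 2 to compound 3 in this assay. The estimate for compound 3 in this assay is 150000 nM, with a range from 50000 nM to 500000 nM.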

Compound 3, half-maximal inhibitory concentration: > 100000 nM
Compound 3 gave a limit, no number (the forecaster's own chance of this, stated with the estimate: 85%); the middle value does not contradict the limit.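

Compound 3 also sits at a limit and gives no number, as do compound 1 and compound 2, so no step among them can be read: the limit of > 100000 nM in this assay, at which 3 of the 3 values shown sit.

The compounds shown leave open whether any group on an oxygen next to a carbonyl group would give a number rather than a limit.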